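The source may hold more compounds than are shown below. What is called first, only, known or untested is meant among the compounds shown, and "the series" means these compounds.

For the measured compounds named here, compound 1 `CCOC(=O)CCO/N=C(/c1ccc(OC)c(OC)c1OC)c1cccc2ccccc12` is the only member of the series with a number in a functional assay on HCT-116 cells (Homo sapiens) for inhibition, read by sulforhodamine B assay, with a stated time of 48 h (on this read-out lower numbers stand for stronger inhibition and higher numbers for weaker inhibition), where compound 1 gives 10000 nM. Compound 2 `COc1ccc(C(O)(Cc2ccc(C)cc2)c2cccc3ccccc23)c(OC)c1OC` sits at the limit of > 20000 nM in this assay, at which 1 of the 2 values shown sits; in this assay compound 2 is reported as > 20000 nM, which is a limit and not a number. Compound 3 `CCOC(=O)CO/N=C(/c1ccc(OC)c(OC)c1OC)c1cccc2ccccc12` differs from compound 1 by ethoxycarbonyl in place of (ethoxycarbonyl)methyl on a saturated chain carbon bound to an oxygen on an unsaturated carbon, a shorter linker to the ester. Going by the values given here, no measured pair shows the effect of such a change, so the step from compound 1 to compound 3 is expected to stay within the scatter, no change at the digits printed from compound 1 to compound 3 (within the scatter). Compound 3 is estimated at 10000 nM, between 4000 nM and 25000 nM.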

Compound 3, half-maximal inhibitory concentration: 3360 nM
The estimate for compound 3 lay 3.0-fold (0.47 log units) above the measured number; the measured number lies below the stated range.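

For the compounds shown here, replacing 2-(ethoxycarbonyl)ethoxy with (ethoxycarbonyl)methoxy on the shared core gives the first readable step: in this assay, there is a 3.0-fold lower number from compound 1 to compound 3 (0.47 log units; beyond the scatter). The chain leading to the ester is therefore a position where a small change moves the number beyond the scatter. Nothing measured here accounts for the step.

A single pair gives one direction at one position and no trend with chain length. Going by these compounds, whether a longer chain would raise the number, or a carboxylic acid or an amide in place of the ethyl ester would keep the lower number of compound 3, remains open.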